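This account rests on a few compounds, and the source may have more. Where it says the series, first, only, none or still open, it means among the compounds named here.

Working notes on the series. In a functional assay on PC-3 cells (Homo sapiens) for cytotoxicity, read by MTT assay, with a stated time of 72 h (on this read-out lower numbers stand for stronger inhibition and higher numbers for weaker inhibition), compound 1 `COc1ccc(Cn2ncc3cc(C(=N)Nc4ccc(N5CCN(C)CC5)cc4)ncc32)cc1` gives 6100 nM. Compound 2 `CN1CCN(c2ccc(NC(=N)c3cc4c(-c5ccccc5)nn(C)c4cn3)cc2)CC1` gives 5900 nM in this assay, a number within the scatter of compound 1, so the two stand together. Compound 3 `COc1ccc(Cn2nc(-c3ccccc3)c3cc(C(=N)Nc4ccc(N5CCN(C)CC5)cc4)ncc32)cc1` is not yet measured. Relative to compound 2 the change is 4-methoxyphenyl in place of hydrogen on a saturated chain carbon bound to an aromatic nitrogen. The same 4-methoxybenzyl group is present in compound 1, whose 6100 nM sits in the same range as compound 2. The step of a 1.2-fold lower number from compound 2 to compound 3 (0.07 log units; within the scatter) is therefore expected to stay inside the scatter. Compound 3 is estimated at 5000 nM, within 2000 nM to 15000 nM.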

Compound 3, half-maximal inhibitory concentration: 3990 nM
Estimate against measurement, compound 3: 1.3-fold (0.10 log units) above; measured number inside the range.
By their numbers in this assay, from the lowest: compounds 3, 2 and 1 (each within the scatter of the next).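

With both groups on one core, in this assay 4-methoxyphenyl in place of hydrogen on a saturated chain carbon bound to an aromatic nitrogen gives a 1.5-fold lower number from compound 2 to compound 3 (0.17 log units; within the scatter) and phenyl in place of hydrogen on an aromatic carbon gives a 1.5-fold lower number from compound 1 to compound 3 (0.18 log units; within the scatter) in the same read-out. Neither step leaves the scatter, so each place accepts its group without a readable change in the number. Nothing on hand bears on a reason for this. Still open, from the compounds shown here alone, is whether an amine or a carboxylic acid in place of the 4-methoxyphenyl or the phenyl would move the number beyond the scatter.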